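The source may hold more compounds than are shown below. What is called first, only, known or untested is meant among the compounds shown, and "the series" means these compounds.

Measured in a functional assay on WHCO1 cells (Homo sapiens) for antiproliferative activity, read by MTT assay, with a stated time of 48 h; on this read-out lower numbers stand for stronger inhibition and higher numbers for weaker inhibition:
- compound 1 `C=CCSSC=CC[S+]([O-])Cc1ccc(OC)cc1`: 7400 nM
- compound 2 `C=CCSS/C=C/C[S+]([O-])CCC`: 37000 nM
- compound 3 `C=CCSS/C=C\C[S+]([O-])CCCN1C(=O)c2ccccc2C1=O`: 33000 nM

Compound 1 has the lowest number of these three, and so the strongest inhibition of cell growth. Its gaps to both of the others lie beyond the usual scatter of repeated measurements, while compound 2 and compound 3 lie within that scatter of each other.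

The next compound to be tested is compound 4 `COc1ccc(CSSC=CC[S+]([O-])Cc2ccc(OC)cc2)cc1`. It is made from compound 1 by placing 4-methoxyphenyl in place of vinyl on a saturated chain carbon bound to a sulfur.

Among the compounds with values here, no two measured compounds differ in one place only, so no measured step shows directly what such a change does in this assay. There is only an indirect hint. Compound 1, at 7400 nM, already carries a 4-methoxyphenyl group, whereas compound 2 and compound 3 carry none. With three compounds, that is thin evidence, and compound 4 would carry the group twice. The expectation is therefore for no change beyond the scatter, and the estimated 1.1-fold lower number from compound 1 to compound 4 (0.02 log units; within the scatter) is small. For compound 4 the estimated value is 7000 nM, with an expected range of 2800 nM to 18000 nM.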

Compound 4, half-maximal inhibitory concentration: 2100 nM
The estimate for compound 4 lay 3.3-fold (0.52 log units) above the measured number, and the stated range ends above it.
By their numbers in this assay, from the lowest: compound 4; then compound 1; then compounds 3 and 2 (each within the scatter of the next).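

In this assay, within the data shown here, placing 4-methoxyphenyl in place of vinyl on a saturated chain carbon bound to a sulfur gives a 3.5-fold lower number from compound 1 to compound 4 (0.55 log units; beyond the scatter), which lies beyond the usual scatter and is the first step here that isolates a single change. This position is therefore not indifferent to what it carries: the small vinyl group can give way to a larger group bearing an aromatic ring, and inhibition of cell growth becomes stronger rather than being lost. Nothing available here explains why the number falls, as no measurement of any property of the two groups accompanies this step.

This single step cannot separate the contribution of the aromatic ring from that of the methoxy group on it, or from the larger size of the new group, so a plain phenyl group or a longer saturated chain in the same place would be informative comparisons. It also leaves open whether the same swap would have a similar effect if the 4-methoxyphenyl group at the other end of compound 1 were replaced by another group, such as an amine.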